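Pyridinylpiperazine in place of the bipiperidine side chain

The compounds below may be only part of what the source reports. "The series", "measured", "known", "first", "only" and "open" are said of these compounds alone.

Compound 1, `COc1cc2c(Nc3ccc(C#N)cc3)ncnc2cc1OCCCN1CCC(C)CC1`, gives 7900 nM in a functional assay on SH-SY5Y cells (Homo sapiens) for antiproliferative activity, read by MTT assay, with a stated time of 72 h; a lower number here means a stronger inhibitor, a higher number a weaker inhibitor.
Compound 2, `COc1cc2c(Nc3ccc(C#N)cc3)ncnc2cc1OCCCN1CCc2ccccc2C1`, reaches only > 100000 nM in this assay, which is a limit of the assay and not a number.
Compound 3, `COc1cc2c(Nc3ccc(C#N)cc3)ncnc2cc1OCCCN1CCC(N2CCCCC2)CC1`, gives 9810 nM in this assay.

Of the two numbers, compound 3 holds the higher one, but its gap to compound 1 lies within the scatter: a 1.2-fold higher number from compound 1 to compound 3 (0.09 log units; within the scatter). Compound 2 sits at the limit, (the limit of > 100000 nM in this assay, at which 1 of the 3 values shown sits).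

The step to compound 4, `COc1cc2c(Nc3ccc(C#N)cc3)ncnc2cc1OCCCN1CCN(c2ccncc2)CC1`, is 4-(pyridin-4-yl)piperazin-1-yl in place of 4-(piperidin-1-yl)piperidin-1-yl on a saturated chain carbon, three bonds along the chain from an oxygen on an aromatic ring. Going by the values given here, two measured steps bear on it, both at the same chain carbon. First, an at least 12-fold higher number from compound 1 to compound 2 (1.10 log units; beyond the scatter). Second, an at least 10-fold lower number from compound 2 to compound 3 (1.00 log units; beyond the scatter). The one amine that carries an aromatic ring, in compound 2, gave the weakest result, while the two fully saturated amines of compound 1 and compound 3 sit close together. Compound 4 again brings an aromatic ring into this position, though as a pendant pyridin-4-yl on a piperazine rather than as a fused bicycle.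

In this assay compound 4 is therefore expected to be weaker than compound 3, by the step of a 3.1-fold higher number from compound 3 to compound 4 (0.49 log units; beyond the scatter). The estimate for compound 4 is 30000 nM, expected to fall between 9000 nM and 100000 nM.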

Compound 4, half-maximal inhibitory concentration: 31600 nM
Beside the measured number, compound 4's estimate is 1.1-fold (0.02 log units) below it; the range from low to high includes it.
By their numbers in this assay, from the lowest: compounds 1 and 3 (each within the scatter of the next); then compound 4. At a limit, above all of these: compound 2.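

With a 3.2-fold higher number from compound 3 to compound 4 (0.51 log units; beyond the scatter) and a 4.0-fold higher number from compound 1 to compound 4 (0.60 log units; beyond the scatter), this position in this assay now tells a pendant pyridin-4-yl on a piperazine apart from both saturated amines, whereas compound 1 and compound 3 had stayed within the scatter of each other. The change from compound 3 to compound 4 leaves the count of heavy atoms unchanged, so the step appears with no change in the size of the group by that count, and among the four compounds shown both amines that carry an aromatic ring lie above the two saturated ones, with no compound going against this. A pendant aromatic ring also does not match a fused one, as an at least 3.1-fold lower number from compound 2 to compound 4 (0.50 log units; beyond the scatter) shows, but compound 2 stands at a limit of the assay and not at a number, so that step gives only a bound: the limit of > 100000 nM in this assay, at which 1 of the 4 values shown sits.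

The compounds shown leave open whether the step follows the pyridine nitrogen or the aromatic ring itself, a question on which a phenyl or a pyridin-2-yl on the same piperazine would bear. They also leave open whether the same order among these amines would hold with a longer chain between the oxygen and the amine.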